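This account rests on a few compounds, and the source may have more. Where it says the series, first, only, none or still open, it means among the compounds named here.

Two compounds share one core, and a piece at its edge has been varied. Compound 1, `CCCn1c(=O)[nH]c2nc(-c3ccc(S(=O)(=O)N4CCN(c5cccc(F)c5)CC4)cc3)[nH]c2c1=O`, carries a 3-fluorophenyl group on an amine nitrogen in a ring. In an assay on CHO cells for displacement of a labelled ligand from adenosine receptor A3 (Homo sapiens), read by scintillation counting, with a stated time of 45 min, tested at 1 uM, in the presence of a further agent that is not named here (on this read-out higher numbers stand for more inhibition at the one concentration tested (going by the name of the read-out) and lower numbers for less inhibition), compound 1 gives 44%. Compound 2, `CCCn1c(=O)[nH]c2nc(-c3ccc(S(=O)(=O)N4CCN(c5ccccc5)C(C)C4)cc3)[nH]c2c1=O`, differs from compound 1 in more than one place, so its number cannot be laid on any single change; in this assay compound 2 gives -2%. Of these two numbers compound 1 stands at the top, and the gap to compound 2 lies beyond the scatter of repeated measurements.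

Compound 3, `CCCn1c(=O)[nH]c2nc(-c3ccc(S(=O)(=O)N4CCN(c5ccc(Cl)cc5F)CC4)cc3)[nH]c2c1=O`, has not yet been measured. It differs from compound 1 in one place: 4-chloro-2-fluorophenyl in place of 3-fluorophenyl on an amine nitrogen in a ring. Among the compounds with values here, no measured pair shows what this kind of change does here, so there is no step to lean on, only the number for compound 1 itself. The estimate for compound 3 in this assay is 35%, with a range from 5% to 60%. This corresponds to an expected step of a number 9 percentage points lower from compound 1 to compound 3 (within the scatter), a small fall that may well sit within the scatter.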

Compound 3, a percentage reported as inhibition, at one concentration (the size of the read-out at that concentration, not a potency): 14%
Estimate against measurement, compound 3: 21 percentage points above; the measured number falls inside the stated range.
By their numbers in this assay, from the lowest: compound 2; then compound 3; then compound 1.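

Within the data shown here, this is the first step at this position, the phenyl ring on an amine nitrogen in a ring of the shared core, and it shows that the position is sensitive to what that phenyl ring carries: in this assay, 4-chloro-2-fluorophenyl in place of 3-fluorophenyl gives a number 30 percentage points lower from compound 1 to compound 3 (beyond the scatter). The two groups match in what can be counted for the ring, hydrogen-bond donors, hydrogen-bond acceptors and charge, and differ only in the added chlorine and in where the fluorine sits, so a change limited to these ring substituents is enough to shift the reading. Nothing measured here says why the number falls.

This single step cannot separate the added chlorine from the relocated fluorine, so it remains open which of the two accounts for the fall; 4-chlorophenyl and 2-fluorophenyl on the same nitrogen would pull them apart. It also leaves open how this position responds to substituents that are not halogens, such as a methoxy group or a nitrile on the phenyl ring.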